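Aryl urea variation on a chloropyrazine benzylamine series

The compounds below may be only part of what the source reports. "The series", "measured", "known", "first", "only" and "open" are said of these compounds alone.

Measured compounds:
compound 1, `O=C(Nc1cccc(CNc2nccnc2Cl)c1)NC1CCCCC1`, > 40000 nM
compound 2, `Cc1cccc(NC(=O)Nc2cccc(CNc3nccnc3Cl)c2)c1`, 9570 nM
compound 3, `COc1ccc(NC(=O)Nc2cccc(CNc3nccnc3Cl)c2)cc1`, 9820 nM

In a functional assay on T-24 cells (Homo sapiens) for antiproliferative activity, read by MTT assay, with a stated time of 48 h (on this read-out lower numbers stand for stronger inhibition and higher numbers for weaker inhibition), compound 1 gives only a limit, > 40000 nM, and no number; this is the limit of > 40000 nM in this assay, at which 1 of the 3 values shown sits. Compound 2 gives 9570 nM in this assay, and compound 3 gives 9820 nM. Among the two numbers shown, compound 3 stands highest, but its nearest neighbour is compound 2 and the step of a 1.0-fold higher number from compound 2 to compound 3 (0.01 log units; within the scatter) keeps the two within the scatter, so no order between them can be read. The two steps from the cyclohexyl urea, an at least 4.1-fold lower number from compound 1 to compound 2 (0.62 log units; beyond the scatter) and an at least 4.0-fold lower number from compound 1 to compound 3 (0.60 log units; beyond the scatter), are the only ones beyond the scatter.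

Compound 4, `CCc1ccccc1NC(=O)Nc1cccc(CNc2nccnc2Cl)c1`, is not yet measured. It differs from compound 3 as follows: 2-ethylphenyl in place of 4-methoxyphenyl on an amide-type nitrogen. The step that bears most directly on this change is the aryl-to-aryl swap, a 1.0-fold higher number from compound 2 to compound 3 (0.01 log units; within the scatter), which stayed within the scatter; the aryl group is kept, so the larger steps from compound 1 do not apply. For compound 4 a step of a 1.0-fold lower number from compound 3 to compound 4 (0.01 log units; within the scatter) is therefore expected, within the scatter. Compound 4 is estimated at 9500 nM, with a range from 4000 nM to 25000 nM.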

Compound 4, half-maximal inhibitory concentration: 8720 nM
Beside the measured number, compound 4's estimate is 1.1-fold (0.04 log units) above it; the range from low to high includes it.
By their numbers in this assay, from the lowest: compounds 4, 2 and 3 (each within the scatter of the next). At a limit, above all of these: compound 1.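

In this assay, the 2-ethylphenyl group on the amide-type nitrogen cannot be told apart from either earlier aryl group: a 1.1-fold lower number from compound 3 to compound 4 (0.05 log units; within the scatter), and a 1.1-fold lower number from compound 2 to compound 4 (0.04 log units; within the scatter). The 2-ethylphenyl, 3-methylphenyl and 4-methoxyphenyl groups therefore give indistinguishable values, although the 2-ethylphenyl group carries no hydrogen-bond acceptor and the 4-methoxyphenyl group carries one, while the separation from the cyclohexyl urea now holds for a third aryl group, with none of the aryl compounds shown going against it: an at least 4.5-fold lower number from compound 1 to compound 4 (0.66 log units; beyond the scatter). Compound 1 gives a limit and not a number, so this last step has only a bound: the limit of > 40000 nM in this assay, at which 1 of the 4 values shown sits.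

The compounds shown leave open whether any substituent on the phenyl ring can separate itself from these three, for instance an amine or a carboxylic acid, since only alkyl and methoxy groups appear here. Also open, on these data alone, is whether a pyridine ring in place of the phenyl ring, or a benzyl group on the same nitrogen, would give a value beyond the scatter of the aryl ureas.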